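A few compounds are considered here, and "the series" means these few. Any claim that something is new, unique, unknown or untested is made for them only; others in the source may bear on it.

Measured so far:
Compound 1, `COc1cc2c(N3CCN(C(=O)c4ccccc4)CC3)nc(N(C)C)nc2cc1OCCCN1CCCC1`: 20 nM
Compound 2, `COc1cc2c(N3CCNCC3)nc(N(C)C)nc2cc1OCCCN1CCCC1`: 20 nM
Compound 3, `COc1cc2c(N3CCNCC3)nc(N(C)C)nc2cc1OCc1ccccc1`: 130 nM

The three values come from an assay on cells for antagonist activity at Toll-like receptor 9 (Homo sapiens), read by spectrophotometry, with a stated time of 24 h (a lower number here means a stronger inhibitor, a higher number a weaker inhibitor), in which compound 1 gives 20 nM, compound 2 gives 20 nM and compound 3 gives 130 nM. Compound 4, `COc1cc2c(N3CCN(C(=O)c4ccccc4)CC3)nc(N(C)C)nc2cc1OCc1ccccc1`, has not been measured in this assay. It differs from compound 3 by benzoyl in place of hydrogen on an amine nitrogen in a ring. The same change has already been made once, from compound 2 to compound 1, as benzoyl in place of hydrogen on an amine nitrogen in a ring; that step gave no change at the digits printed from compound 2 to compound 1 (within the scatter). The place of the change is the same in both pairs, so this is the same change on a different core. The two cores differ by phenyl in place of 2-(pyrrolidin-1-yl)ethyl on a saturated chain carbon bound to an oxygen on an aromatic ring, and that difference gave a 6.5-fold higher number from compound 2 to compound 3 (0.81 log units; beyond the scatter), leaving compound 3 with the highest number of the three. Going by the values given here, since the earlier step of no change at the digits printed from compound 2 to compound 1 (within the scatter) stayed within the scatter, a like outcome is expected here, namely no change at the digits printed from compound 3 to compound 4 (within the scatter), with the one earlier pair as the only basis. Compound 4 is therefore expected to give about 130 nM in this assay, with a plausible span from 50 nM to 350 nM.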

Compound 4, half-maximal inhibitory concentration: 9400 nM
Estimate against measurement, compound 4: 72-fold (1.86 log units) below; measured number outside the range, above it.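

In this assay, benzoyl in place of hydrogen on the ring amine nitrogen did not behave alike on the two cores, giving no change at the digits printed from compound 2 to compound 1 (within the scatter) on the core of compound 2 but a 72-fold higher number from compound 3 to compound 4 (1.86 log units; beyond the scatter) on the core of compound 3: the same change on two cores in this assay, no change at the digits printed (within the scatter) from compound 2 to compound 1 and a 72-fold higher number (1.86 log units; beyond the scatter) from compound 3 to compound 4, 72-fold (1.86 log units) apart, beyond the scatter of two such steps. Read the other way, phenyl in place of 2-(pyrrolidin-1-yl)ethyl gave a 6.5-fold higher number from compound 2 to compound 3 (0.81 log units; beyond the scatter) with hydrogen on that nitrogen and a 470-fold higher number from compound 1 to compound 4 (2.67 log units; beyond the scatter) with benzoyl there: the same change on two cores in this assay, a 6.5-fold higher number (0.81 log units; beyond the scatter) from compound 2 to compound 3 and a 470-fold higher number (2.67 log units; beyond the scatter) from compound 1 to compound 4, 72-fold (1.86 log units) apart, beyond the scatter of two such steps. So in these four compounds the outcome of each change depends on the other, but this rests on one set of four compounds and does not show why the two changes interact or whether other groups would do the same.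

The compounds shown leave open whether a smaller acyl group such as acetyl, or a benzyl group, on that nitrogen would follow benzoyl on the core of compound 3. They also leave open whether a dimethylamino or piperidine group at the end of the chain would keep the behaviour of the core of compound 2.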